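Chloro in Place of Nitro: Two Weak Inhibitors and a Third

This account rests on a few compounds, and the source may have more. Where it says the series, first, only, none or still open, it means among the compounds named here.

Compound 1 `COc1cc(C2CC(c3ccc([N+](=O)[O-])cc3)=NN2C(C)=O)ccc1OCc1cn(Cc2ccc([N+](=O)[O-])cc2)nn1` was tested in a functional assay on THP-1 cells (Homo sapiens) for inhibition, read by sulforhodamine B assay, tested at 10 uM (a higher number here means more inhibition of growth at the concentration tested, a lower number less inhibition of growth), where compound 1 gives 7%. Compound 2 `COc1ccc(C2CC(c3ccc(OCc4cn(Cc5ccc([N+](=O)[O-])cc5)nn4)cc3)=NN2C(C)=O)cc1OC` in this assay gives 8%. Compound 1 stands lowest of the two numbers, yet the value of compound 2 lies within the usual scatter of it, so the two cannot be told apart, and both show little growth inhibition. Compound 3 `COc1cc(C2CC(c3ccc(Cl)cc3)=NN2C(C)=O)ccc1OCc1cn(Cc2ccc([N+](=O)[O-])cc2)nn1` has not yet been measured. It differs from compound 1 in one place: chloro in place of nitro on an aromatic carbon. For the measured compounds named here, no measured step exists between compounds that differ in this way, so there is no direct guide to its size. Because compound 1 gives 7% and compound 2 gives 8%, a small change is expected. The expected step is a number 1 percentage points higher from compound 1 to compound 3 (within the scatter), within the scatter, with no clear direction. Compound 3 is therefore estimated at 8%, with a range from 0% to 22%.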

Compound 3, percent growth inhibition at one concentration: 17%
Compound 3: middle estimate off by 9 percentage points, on the low side, within the range that was stated.
By their numbers in this assay, from the lowest: compounds 1, 2 and 3 (each within the scatter of the next).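

In this assay, for the compounds shown here, the exchange of 4-nitrophenyl for 4-chlorophenyl gives a number 10 percentage points higher from compound 1 to compound 3 (within the scatter), the first direct reading of this change at this position, para to a large group. The nitro group at this place is therefore not required for the small growth inhibition seen with compound 1, since compound 3, with chloro there, cannot be told apart from it. No evidence is available that bears on the reason for this result. As far as these compounds go, it remains open whether an amine, a carboxylic acid or a methoxy group on this aromatic carbon would give a reading beyond the scatter of compound 1. Also open, from the compounds shown here alone, is what would follow from replacing the other nitro group, which compound 1 and compound 3 share, with chloro.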